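Pyridine for Phenyl in a Vero Cell Cytotoxicity Check

This account rests on a few compounds, and the source may have more. Where it says the series, first, only, none or still open, it means among the compounds named here.

Compound 1 `O=[N+]([O-])c1cn2c(n1)OC[C@@H](OCc1ccc(-c3ccc(F)cc3)s1)C2`: > 128000 nM in an ADME assay on Vero cells (Chlorocebus sabaeus) for cytotoxicity, with a stated time of 72 h (a higher number here means a weaker inhibitor, a lower number a stronger inhibitor), a limit
Compound 2 `O=[N+]([O-])c1cn2c(n1)OC[C@@H](OCc1ccc(-c3ccc(OC(F)(F)F)cc3)s1)C2`: > 128000 nM in this assay, a limit

Compound 1 reaches only the assay limit in this assay, so its standing is a limit and not a number. Compound 2 likewise stops at the limit. The step that the two limits leave unreadable from compound 1 to compound 2 thus gives no readable size. Compound 3 `O=[N+]([O-])c1cn2c(n1)OC[C@@H](OCc1ccc(-c3ccc(F)nc3)s1)C2` differs from compound 1 by 6-fluoropyridin-3-yl in place of 4-fluorophenyl on an aromatic carbon. Within the data shown here, no measured step bears on this change, and both known values sit at the limit (the limit of > 128000 nM in this assay, at which 2 of the 2 values shown sit). Compound 3 is therefore expected to remain at the limit, with no step beyond the scatter expected in a number no higher from compound 1 to compound 3 (the limit leaves the size open). The estimate for compound 3 is 128000 nM, with a range from 64000 nM to 256000 nM.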

Compound 3, half-maximal inhibitory concentration: > 128000 nM
Compound 3 ended at the assay's limit (the forecaster's own chance of this, stated with the estimate: 85%); the middle value sits exactly at the limit.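

No step can be read from compound 1 to compound 3, as both stop at a limit in this assay: the limit of > 128000 nM in this assay, at which 3 of the 3 values shown sit.

The compounds shown leave open whether 6-fluoropyridin-3-yl in place of 4-fluorophenyl changes the true half-maximal inhibitory concentration at all.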